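The source may hold more compounds than are shown below. What is called first, only, known or untested is meant among the compounds shown, and "the series" means these compounds.

Within the data shown here, compound 2 `CC1(C)CC(=O)C(CC(=O)c2ccccc2)=C(NNC(=N)N)C1` gives 76% in a functional assay on the whole organism (strain CF) for inhibition, with Mus musculus as the target, at a dose of 25 mg/kg by the oral route (a higher number here means more inhibition at the dose given (going by the name of the read-out), a lower number less inhibition), the higher of the two numbers known so far; compound 1 `CCOC(=O)NNC1=C(CC(=O)c2ccccc2)C(=O)CC(C)(C)C1`, which carries a different group on the amine nitrogen, gives 51% in this assay, so that a number 25 percentage points higher from compound 1 to compound 2 (beyond the scatter). Compound 3 `CC1(C)CC(=O)C(CC(=O)c2ccccc2)=C(NNc2ccncc2)C1` takes the step onward from compound 2: a group of 6 heavy atoms (5 carbon, 1 nitrogen; one six-membered aromatic ring with 1 hetero atom) in place of a group of 3 heavy atoms (1 carbon, 2 nitrogen; no ring), on an amine nitrogen. Among the measured compounds shown here, the one measured step, from compound 1 to compound 2, shows that what sits on this amine nitrogen can move the read-out by a modest amount, but it exchanged two groups unlike the one now entering, and no measured pair shows what a pyridin-4-yl does there. The direction is therefore open, and the expected step from compound 2 to compound 3 is a number 16 percentage points lower from compound 2 to compound 3 (beyond the scatter), with wide uncertainty. For compound 3 the estimate in this assay is 60%, expected to lie between 35% and 85%.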

Compound 3, a percentage reported as inhibition, in the whole organism at one dose (the size of the read-out at that dose, not a potency): 76%
Compound 3: middle estimate off by 16 percentage points, on the low side; the range from low to high includes it.
By their numbers in this assay, from the lowest: compound 1; then compounds 2 and 3 (each within the scatter of the next).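

In this assay, pyridin-4-yl in place of the open-chain group of compound 2 gives no change at the digits printed from compound 2 to compound 3 (within the scatter), so this amine nitrogen accepts a six-membered aromatic ring with no loss in the read-out at this dose. Set against ethoxycarbonyl, the same ring gives a number 25 percentage points higher from compound 1 to compound 3 (beyond the scatter), which leaves compound 1 apart from compound 2 and compound 3 and shows that two quite different groups can reach the same level here. Nothing measured on these compounds explains this result.

The compounds shown leave open whether the ring nitrogen of pyridin-4-yl matters, which a plain phenyl or a pyridin-2-yl on this amine nitrogen would test. They also leave open whether a small acetyl group would fall with ethoxycarbonyl or stand with the other two groups.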